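Salicylanilide series: chloro for fluoro on the acid ring

This account rests on a few compounds, and the source may have more. Where it says the series, first, only, none or still open, it means among the compounds named here.

Three compounds of this salicylanilide series have numbers in a functional assay on HL-60 cells (Homo sapiens) for cytotoxicity, read by luminescence and CellTiter-Glo, with a stated time of 3 days; a higher number here means a weaker inhibitor, a lower number a stronger inhibitor. Compound 1 `O=C(Nc1ccc(C(F)(F)F)c(Cl)c1)c1cc(Cl)ccc1O` gives 460 nM; compound 2 `O=C(Nc1ccc(Cl)c(Cl)c1)c1cc(F)ccc1O` gives 660 nM; compound 3 `O=C(Nc1ccc(OC(F)(F)F)c(Cl)c1)c1cc(F)ccc1O` gives 550 nM. Compound 3 stands second highest of the three, its gap to compound 1 and its gap to compound 2 both within the scatter. Among the compounds with values here, the only single-point step among them, a 1.2-fold lower number from compound 2 to compound 3 (0.08 log units; within the scatter), concerns the aniline ring and does not touch the change now in question.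

Compound 4 `O=C(Nc1ccc(OC(F)(F)F)c(Cl)c1)c1cc(Cl)ccc1O` differs from compound 3 by one change: chloro in place of fluoro on an aromatic carbon. Within the data shown here, no measured pair exchanges fluoro for chloro at this place, so there is no direct precedent. The nearest indication is compound 1, which carries chloro on the same ring and gives 460 nM, a number within the scatter of compound 3. The expected step of a 1.2-fold lower number from compound 3 to compound 4 (0.09 log units; within the scatter) is therefore small and not beyond the scatter. Compound 4 is estimated at 450 nM, with a range from 200 nM to 1000 nM.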

Compound 4, half-maximal inhibitory concentration: 450 nM
Compound 4: middle estimate and measured number agree at the digits printed, within the range that was stated.
By their numbers in this assay, from the lowest: compounds 4, 1, 3 and 2 (each within the scatter of the next).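

In this assay, the exchange of fluoro for chloro at this place, para to a hydroxy group, now has a direct pair behind it: a 1.2-fold lower number from compound 3 to compound 4 (0.09 log units; within the scatter). With chloro held at that place, trifluoromethoxy in place of trifluoromethyl on an aromatic carbon gives a 1.0-fold lower number from compound 1 to compound 4 (0.01 log units; within the scatter), so neither single change separates its two compounds in this assay. Nothing measured here offers an explanation for these small steps.

On these data alone, whether a group of another kind at the place para to the hydroxy group, such as an amine, a carboxylic acid or a nitrile, would give a step beyond the scatter remains open. Also open, as far as these compounds go, is what a methoxy group in place of the hydroxy group would do to the number, since all four compounds share that hydroxy group.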